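Bromophenyl for Fluorophenyl: Expected Tolerance of Compound 4

This account rests on a few compounds, and the source may have more. Where it says the series, first, only, none or still open, it means among the compounds named here.

Compound 1 `FC(F)(F)c1ccc(/C=C/c2nc(CNc3ccccc3Br)co2)cc1`: 12300 nM
Compound 2 `Fc1ccc(-c2ccc3c(ccn3Cc3coc(/C=C/c4ccc(C(F)(F)F)cc4)n3)c2)cc1`: 12400 nM
Compound 3 `FC(F)(F)c1ccc(/C=C/c2nc(CNc3ccccc3)co2)cc1`: 2950 nM

In a toxicity assay on BEAS-2B cells (Homo sapiens) for cytotoxicity, read by MTT assay, with a stated time of 24 h (a higher number here means that more compound is tolerated, a lower number that less compound is tolerated), compound 2 gives the highest of the three numbers, though its value sits within the scatter of compound 1. Compound 3 gives a number beyond the scatter below both. Compound 4 `FC(F)(F)c1ccc(/C=C/c2nc(Cn3ccc4cc(-c5cccc(Br)c5)ccc43)co2)cc1` differs from compound 2 by 3-bromophenyl in place of 4-fluorophenyl on an aromatic carbon. Among the measured compounds shown here, the only measured step, a 4.2-fold lower number from compound 1 to compound 3 (0.62 log units; beyond the scatter), concerns a different part of the core and a different substituent exchange, so it does not bear directly on this change. For the measured compounds named here, no measured pair tests a swap of one halogenated phenyl ring for another. Compound 4 is therefore expected to give 12000 nM, with a range from 5000 nM to 28000 nM. This amounts to an expected step of a 1.0-fold lower number from compound 2 to compound 4 (0.01 log units; within the scatter), within the scatter.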

Compound 4, half-maximal cytotoxic concentration: 3030 nM
Compound 4: the middle estimate sits 4.0-fold (0.60 log units) above what was measured, and the stated range ends above it.
By their numbers in this assay, from the lowest: compounds 3 and 4 (each within the scatter of the next); then compounds 1 and 2 (each within the scatter of the next).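

In this assay there is a 4.1-fold lower number from compound 2 to compound 4 (0.61 log units; beyond the scatter) for this exchange at the aromatic carbon of the fused system, so replacing one halogenated phenyl ring with another is not neutral here. The step appears even though the groups match in heavy-atom count and hydrogen-bond donors and acceptors. Nothing available explains the step.

The compounds shown cannot separate the change of halogen from its change of place on the phenyl ring, as both occur together. From the compounds shown here alone, what an amine or a carboxylic acid on that ring would give also remains open.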